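A few compounds are considered here, and "the series" means these few. Any claim that something is new, unique, unknown or untested is made for them only; others in the source may bear on it.

Working notes on the shared core of compound 2 `Cc1ccccc1NC(=O)Cn1c(=O)c(/C=C\c2ccncc2)nc2ccccc21`, varied at the amide-type nitrogen. In a functional assay on cells (Homo sapiens) for inhibition, read by MTT assay, with a stated time of 24 h (on this read-out lower numbers stand for stronger inhibition and higher numbers for weaker inhibition), compound 2 gives 69700 nM. Compound 1 `O=C(Cn1c(=O)c(/C=C\c2ccncc2)nc2ccccc21)Nc1ccc(Cl)cc1` carries 4-chlorophenyl at that nitrogen. In this assay compound 1 reaches only the limit of > 100000 nM. Within the data shown here, compound 2 thus holds the only actual number in the set; the other value is a limit, (the limit of > 100000 nM in this assay, at which 1 of the 2 values shown sits). Among the measured compounds shown here, the single measured step, an at least 1.4-fold lower number from compound 1 to compound 2 (0.15 log units; that floor lies within the scatter), has a floor within the scatter.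

Compound 3 `O=C(Cn1c(=O)c(/C=C\c2ccncc2)nc2ccccc21)Nc1ccc(Cl)c(Cl)c1` differs by 3,4-dichlorophenyl in place of 2-methylphenyl on an amide-type nitrogen. For the measured compounds named here, the one step on record bears on this change only loosely, since it runs from a chlorophenyl to a methylphenyl and reads as weak-to-weaker territory throughout. Going back toward a chlorinated phenyl suggests a number not lower than that of compound 2, possibly again at the limit. The step expected is therefore a 1.4-fold higher number from compound 2 to compound 3 (0.16 log units; within the scatter), a weakening or none beyond the scatter. The estimate for compound 3 is 100000 nM, within a range of 40000 nM to 300000 nM.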

Compound 3, half-maximal inhibitory concentration: > 100000 nM
Compound 3: only a limit was reported; the forecaster's own chance of this, stated with the estimate: 50%; the middle value sits exactly at the limit.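

The new result adds a second chlorinated phenyl at the amide-type nitrogen, but it does not separate this group from 2-methylphenyl: an at least 1.4-fold higher number from compound 2 to compound 3 (0.15 log units; that floor lies within the scatter). From the compounds shown here alone, compound 1 and compound 3 are both reported only as limits, so the step between them cannot be read, and the effect of chloro in place of hydrogen on an aromatic carbon remains unknown. Among these compounds, both chlorinated compounds now rest at the same limit, leaving compound 2 as the only actual number in the set: the limit of > 100000 nM in this assay, at which 2 of the 3 values shown sit.

Going by these compounds, whether any group at this nitrogen can give a number clearly lower than that of compound 2 remains open. Also open, on these data alone, is how a phenyl carrying a carboxylic acid or a dimethylamino group, or a longer alkyl chain, would read out at this position.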